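The source may report more compounds than this note shows. Statements on the series, on what has been measured and on what is new or still open speak of the compounds shown alone.

Compound 1 `Nc1ccccc1NC(=O)c1ccc(NCC(=O)Nc2ccc([N+](=O)[O-])cc2)cc1`: 42500 nM
Compound 2 `Nc1ccccc1NC(=O)c1ccc(NCC(=O)Nc2cccc([N+](=O)[O-])c2)cc1`: 52000 nM

In a functional assay on U-251 cells (Homo sapiens) for inhibition, read by MTT assay, with a stated time of 2 days (a lower number here means a stronger inhibitor of growth, a higher number a weaker inhibitor of growth), compound 2 gives 52000 nM, which lies within the scatter of compound 1. Compound 3 `Cc1ccc(NC(=O)CNc2ccc(C(=O)Nc3ccccc3N)cc2)cc1` is the next to be read, and it carries 4-methylphenyl in place of 3-nitrophenyl on an amide-type nitrogen, with 4-methylphenyl in place of 3-nitrophenyl on an amide-type nitrogen. Going by the values given here, only one measured step bears on this, a 1.2-fold higher number from compound 1 to compound 2 (0.09 log units; within the scatter), and it exchanges 4-nitrophenyl for 3-nitrophenyl. Among the compounds with values here, no measured compound carries 4-methylphenyl, so no shift beyond the scatter is expected in this assay. The expected change is a 1.2-fold lower number from compound 2 to compound 3 (0.06 log units; within the scatter). For compound 3 the estimated value is 45000 nM, with an expected range of 20000 nM to 95000 nM.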

Compound 3, concentration for total growth inhibition: > 100000 nM
Compound 3 was reported as a limit; the forecaster's own chance of this, stated with the estimate: 12%; at least 2.2-fold (0.34 log units) between middle value and limit.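

In this assay compound 3 is reported only as a limit, > 100000 nM. Methyl in place of nitro on the aromatic carbon gives an at least 2.3-fold higher number from compound 1 to compound 3 (0.37 log units; beyond the scatter), so the group on this amide-type nitrogen does matter, which the earlier shift of the nitro group did not show, while an at least 1.9-fold higher number from compound 2 to compound 3 (0.28 log units; that floor lies within the scatter) does not separate that pair on its own. The true size of both steps stays unknown: the limit of > 100000 nM in this assay, at which 1 of the 3 values shown sits.

The compounds shown leave open whether an amine or a methoxy group in place of the nitro would stay near compound 1 or also reach the limit.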